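A few compounds are considered here, and "the series" means these few. Any claim that something is new, unique, unknown or untested is made for them only; others in the source may bear on it.

Two compounds share a core and differ only in the group carried on the benzyl ring. Compound 1 `Oc1ccc(CNc2cc(C(F)(F)F)cc3[nH]ncc23)cc1` bears a hydroxy group, and in an assay for inhibition of Indoleamine 2,3-dioxygenase 1 (Homo sapiens), with stated times of 10 min and 60 min, tested at 10 uM (a higher number here means a stronger effect of the compound at the concentration tested, a lower number a weaker effect), compound 1 gives 37%. Compound 2 `O=C(O)c1cccc(CNc2cc(C(F)(F)F)cc3[nH]ncc23)c1` bears a carboxy group instead, and in this assay compound 2 gives 11%. Among the two numbers known, compound 2 stands lowest, and the gap to compound 1 lies beyond the usual scatter of repeated measurements.

Compound 3 `Nc1cccc(CNc2cc(C(F)(F)F)cc3[nH]ncc23)c1` has not yet been measured. It is compound 2 with one change: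

amino in place of carboxy on an aromatic carbon

Among the measured compounds shown here, no step between two measured compounds covers this exact change, so its effect can only be guessed from what the two numbers show. Since compound 2 sits at the low end with 11% and compound 1 with its hydroxy group reaches 37%, the step from carboxy to amino is expected to move upward in this assay by a moderate amount, probably beyond the scatter, though a flat outcome cannot be excluded. The expected step is a number 19 percentage points higher from compound 2 to compound 3 (beyond the scatter). For compound 3 the estimate in this assay is 30%, with a plausible range from 10% to 55%.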

Compound 3, a percentage reported as inhibition, at one concentration (the size of the read-out at that concentration, not a potency): 24%
Beside the measured number, compound 3's estimate is 6 percentage points above it; low and high end bracket the measured number.
By their numbers in this assay, from the lowest: compound 2; then compound 3; then compound 1.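

In this assay, among the compounds shown here, the step of a number 13 percentage points higher from compound 2 to compound 3 (beyond the scatter) is the first direct evidence that this aromatic carbon, meta to a large group, responds to the group it carries: carboxy leaves and amino enters, and the number moves beyond the scatter although both groups have the same counts of hydrogen-bond donors and acceptors and no net charge. The step of a number 13 percentage points lower from compound 1 to compound 3 (beyond the scatter) places the amino compound between the other two, but 3-aminophenyl replaces 4-hydroxyphenyl here, so both the group and its place on the ring change, and this step cannot be assigned to either alone. Nothing available explains why either step has its direction or size.

As far as these compounds go, it remains open whether hydroxy on the same aromatic carbon as the amino group of compound 3 would match the number of compound 1, or whether amino at the ring position of the hydroxy group would do so. From the compounds shown here alone, how a methoxy group, a carboxamide or a nitrile on this carbon would compare with amino and carboxy also remains unknown.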